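The source may hold more compounds than are shown below. What is called first, only, known or untested is meant among the compounds shown, and "the series" means these compounds.

Measured so far, read in an ADME assay on Vero cells (Chlorocebus sabaeus) for cytotoxicity, read by neutral red uptake, tested at 197 ug/mL; a lower number here means a stronger effect, a higher number a weaker effect of the compound at the concentration tested:
- compound 1 `O=C1CSC(c2c(Cl)cccc2Cl)N1CCN1CCCCC1`: 75%
- compound 2 `O=C1CSC(c2cccc(O)c2)N1CCN1CCCCC1`: 100%
- compound 3 `O=C1CSC(c2ccccc2[N+](=O)[O-])N1CCN1CCCCC1`: 100%

The shared core is carried unchanged through the series; only the aryl substituent varies. Compound 2 stands level with compound 3 at the digits reported, and these two together give the highest numbers of the three in this assay, meaning the weakest effect on the cells. Compound 1 lies a step lower, beyond the scatter, and so shows a stronger effect than compound 2 and compound 3. Among the measured compounds shown here, no pair here differs in a single place, so no counted step between measured compounds is available.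

Compound 4 `O=C1CSC(c2cccc(F)c2)N1CCN1CCCCC1` is the next member to be read. Against compound 2 the change is fluoro in place of hydroxy on an aromatic carbon.

For the measured compounds named here, with no matched step to lean on, the only guide is that compound 2 and compound 3 sit at the top of the range and compound 1 some way under them. For compound 4 a modest downward move, if any, is expected, and none beyond the scatter is assumed with confidence: the estimated step of a number 10 percentage points lower from compound 2 to compound 4 (within the scatter) is small. Compound 4 is thus estimated at 90%, with a range from 65% to 100%.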

Compound 4, a percentage reported as activity, at one concentration (the size of the read-out at that concentration, not a potency): 84%
Beside the measured number, compound 4's estimate is 6 percentage points above it; the range from low to high includes it.
By their numbers in this assay, from the lowest: compounds 1 and 4 (each within the scatter of the next); then compounds 2 and 3 (each within the scatter of the next).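

In this assay, the series gains its first step that can be read at a single place: fluoro in place of hydroxy on an aromatic carbon, meta to a large group, gives a number 16 percentage points lower from compound 2 to compound 4 (beyond the scatter). The earlier compounds shown here, none of which differ in one place, could not show that the number responds to a change at this position; going from 3-hydroxyphenyl to 3-fluorophenyl moves it beyond the scatter, although the change is of one heavy atom for one heavy atom and adds no ring or net charge. No measurement shown explains the step.

From the compounds shown here alone, it remains open whether the step follows the loss of hydroxy, with its hydrogen-bond donor and acceptor, or the arrival of fluoro, a question that the plain phenyl, or a methoxy or an amino group at this same place, could help to separate. Also open, going by these compounds, is whether a carboxylic acid or a trifluoromethyl group here would move the number in the same direction, and whether the same exchange gives a similar step elsewhere on the aromatic ring.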